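Swapping carboxy for chloro in a cytotoxicity read-out

This account rests on a few compounds, and the source may have more. Where it says the series, first, only, none or still open, it means among the compounds named here.

Compound 1 `Cc1cc(NC(=O)Nc2ccccc2N)c2ccccc2n1` and compound 2 `Cc1cc(NC(=O)Nc2ccc(C(=O)O)cc2)c2ccccc2n1` share a core and differ in the group on the outer ring. In an ADME assay on HEK293 cells (Homo sapiens) for cytotoxicity, with a stated time of 72 h (on this read-out lower numbers stand for an effect already at smaller amounts and higher numbers for an effect only at larger amounts of compound), compound 1 gives > 25000 nM, which is a limit of the assay and not a number. Compound 2 gives > 25000 nM in this assay, and this too is only a limit. Within the data shown here, compound 2 therefore stands with the only other measured compound, at the limit of > 25000 nM in this assay, at which 2 of the 2 values shown sit, and neither has an exact value.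

Compound 3 `Cc1cc(NC(=O)Nc2ccc(Cl)cc2)c2ccccc2n1` keeps the core of compound 2 but has chloro in place of carboxy on an aromatic carbon, para to a large group (chloro in place of carboxy on an aromatic carbon). Among the measured compounds shown here, no measured pair shows what this swap does in this assay. The expectation can only start from compound 2, whose > 25000 nM is a limit. The expected change, an at least 1.2-fold lower number from compound 2 to compound 3 (0.09 log units; that floor lies within the scatter), is estimated to stay within the usual scatter. For compound 3, the expected value is 20000 nM, with an estimated range from 7000 nM to 40000 nM.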

Compound 3, half-maximal effective concentration: > 25000 nM
Compound 3: a limit, no number; the forecaster's own chance of this, stated with the estimate: 65%; middle value at least 1.2-fold (0.09 log units) from the limit.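

Compound 3 also gives only a limit and not a number in this assay, so no step from compound 1 or compound 2 to compound 3 can be read, and all three stand together: the limit of > 25000 nM in this assay, at which 3 of the 3 values shown sit.

The compounds shown leave open how far each lies from that limit, and whether chloro in place of carboxy changes this read-out at all.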